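This account rests on a few compounds, and the source may have more. Where it says the series, first, only, none or still open, it means among the compounds named here.

In a functional assay on MDA-MB-231 cells (Homo sapiens) for antiproliferative activity, with a stated time of 5 days (on this read-out higher numbers stand for weaker inhibition and lower numbers for stronger inhibition), two compounds have been measured so far.

Compound 1 `COc1ccc(-n2nc(-c3ccc4ccccc4c3)nc2N2C(=O)COC23C=CC(=O)C=C3)cc1` gives 60 nM
Compound 2 `CC1OC2(C=CC(=O)C=C2)N(c2nc(-c3cccc4ccccc34)nn2-c2ccccc2)C1=O` gives 100 nM

Compound 2 stands within the usual scatter of compound 1, so neither compound can be ranked over the other on these numbers. Compound 3 `O=C1C=CC2(C=C1)OCC(=O)N2c1nc(-c2cccc3ccccc23)nn1-c1ccccc1` has not yet been measured in this assay and is the next point of interest. Compared with compound 2, it shows hydrogen in place of methyl on a saturated ring carbon.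

Going by the values given here, no measured pair in this small set isolates that change, so the data offer no direct guide to its size. Among the compounds with values here, they show only that compound 1 (60 nM) and compound 2 (100 nM) lie within the scatter of each other. A small step is therefore expected in this assay, leaning slightly towards a lower number and not going beyond the scatter. The expected step is a 1.3-fold lower number from compound 2 to compound 3 (0.10 log units; within the scatter) and remains an estimate. For compound 3 the estimated value is 80 nM, with an expected range from 30 nM to 200 nM.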

Compound 3, half-maximal inhibitory concentration: 50 nM
For compound 3 the middle estimate is 1.6-fold (0.20 log units) above the measured one; the measured number falls inside the stated range.
By their numbers in this assay, from the lowest: compounds 3, 1 and 2 (each within the scatter of the next).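

In this assay, going by these compounds alone, compound 2 and compound 3 form the first pair that differ in one place, and the step is a 2.0-fold lower number from compound 2 to compound 3 (0.30 log units; within the scatter). On this saturated ring carbon, next to the ring oxygen, methyl and hydrogen therefore cannot be told apart on these numbers: the methyl is not required for a value in this range, and neither group can be ranked over the other. Nothing at hand bears on the reason for this step, so the result remains a description of the numbers alone.

Methyl and hydrogen are the only two groups shown on this carbon, so it remains open whether an ethyl, a hydroxymethyl or an aminomethyl group there would stay within the scatter of compound 3 or move clearly away from it. Within the data shown here, also open is what the methoxy group of compound 1 contributes, as compound 1 differs from compound 3 in more than one place and no single step isolates that group.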